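Pyrazole attachment point in a urea series of acyltransferase inhibitors

This account rests on a few compounds, and the source may have more. Where it says the series, first, only, none or still open, it means among the compounds named here.

Compound 1 `CSc1cc(C)nc(SC)c1NC(=O)N(Cc1ccccc1)Cc1cccc(-c2ccn(C)n2)c1` and compound 2 `CSc1cc(C)nc(SC)c1NC(=O)N(Cc1ccccc1)Cc1cccc(-c2ccnn2C)c1` share one core, while compound 3 `Cc1cc(C)c(NC(=O)N(Cc2ccc(-c3ccn(C)n3)cc2)C2CCCCCC2)c(C)c1` and compound 4 `Cc1cc(C)c(NC(=O)N(Cc2ccc(-c3ccnn3C)cc2)C2CCCCCC2)c(C)c1` share another; the difference between the two cores is not broken down here. In an assay on microsomes from intestine for inhibition of acyl-CoA:cholesterol acyltransferase (Oryctolagus cuniculus) (a higher number here means a weaker inhibitor, a lower number a stronger inhibitor), compound 1 gives 73 nM, and compound 2 gives 28 nM; the change 1-methyl-1H-pyrazol-5-yl in place of 1-methyl-1H-pyrazol-3-yl on an aromatic carbon brings a 2.6-fold lower number from compound 1 to compound 2 (0.42 log units; beyond the scatter). Compound 3 gives 44 nM in this assay. The change 1-methyl-1H-pyrazol-5-yl in place of 1-methyl-1H-pyrazol-3-yl on an aromatic carbon is the same kind of change, on an aromatic carbon para to a large group rather than meta to a large group. Among the compounds with values here, because the step of a 2.6-fold lower number from compound 1 to compound 2 (0.42 log units; beyond the scatter) went beyond the scatter, a step of a 2.2-fold lower number from compound 3 to compound 4 (0.34 log units; beyond the scatter) is expected for compound 4 in this assay, somewhat tempered since only one such pair has been measured. Compound 4 is therefore estimated at 20 nM, with a likely range from 8 nM to 50 nM.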

Compound 4, half-maximal inhibitory concentration: 24 nM
Beside the measured number, compound 4's estimate is 1.2-fold (0.08 log units) below it; measured number inside the range.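

In this assay, placing 1-methyl-1H-pyrazol-5-yl where 1-methyl-1H-pyrazol-3-yl stood gives a 1.8-fold lower number from compound 3 to compound 4 (0.26 log units; within the scatter), so on this core alone the two compounds cannot be told apart. Set beside the earlier step, the change does not measurably differ between the two cores: the same change on two cores in this assay, a 2.6-fold lower number (0.42 log units; beyond the scatter) from compound 1 to compound 2 and a 1.8-fold lower number (0.26 log units; within the scatter) from compound 3 to compound 4, 1.4-fold (0.15 log units) apart, within the scatter of two such steps The two pairs are therefore compatible with the change carrying over, but two pairs do not establish a rule for the series, and the second step alone does not confirm a real effect on its core.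

From the compounds shown here alone, whether an ethyl group in place of the methyl on the pyrazole nitrogen would behave the same way remains open. So does how the two cores themselves compare.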